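Swapping the thiophene substituent of compound 1

The compounds below may be only part of what the source reports. "The series", "measured", "known", "first", "only" and "open" are said of these compounds alone.

Compound 1, `CSc1ccc(S(=O)(=O)NC(=O)Nc2ccc(Cl)cc2)s1`, carries a 5-(methylsulfanyl)thiophen-2-yl group on the sulfonyl sulfur of the shared core. In a functional assay on the whole organism (6C3HED cells, Mus musculus) for inhibition, at a dose of 300 mg/kg by the oral route (on this read-out lower numbers stand for less inhibition and higher numbers for more inhibition at the one dose given (going by the name of the read-out)), compound 1 gives 62%, the lowest of the three numbers measured. Its nearest neighbour is compound 3, `CCCOc1ccc(S(=O)(=O)NC(=O)Nc2ccc(Cl)cc2)s1`, which in this assay gives 63%; the step of a number 1 percentage points higher from compound 1 to compound 3 (within the scatter) lies within the scatter. The furthest is compound 2, `CCOc1ccc(S(=O)(=O)NC(=O)Nc2ccc(Cl)cc2)s1`, which in this assay gives 96%; the step of a number 34 percentage points higher from compound 1 to compound 2 (beyond the scatter) is large.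

Compound 4, `CCc1csc(S(=O)(=O)NC(=O)Nc2ccc(Cl)cc2)c1`, has not yet been measured. Relative to compound 1 the change is a group of 7 heavy atoms (6 carbon, 1 sulfur; one five-membered aromatic ring with 1 hetero atom) in place of a group of 7 heavy atoms (5 carbon, 2 sulfur; one five-membered aromatic ring with 1 hetero atom), on a sulfonyl sulfur. The two measured steps that bear on it both start from compound 1 and both alter the substituent on the thiophene ring, yet they disagree: a number 34 percentage points higher from compound 1 to compound 2 (beyond the scatter) was a large gain, while a number 1 percentage points higher from compound 1 to compound 3 (within the scatter) was none beyond the scatter. A gain is therefore possible but not assured, and the step of a number 8 percentage points higher from compound 1 to compound 4 (within the scatter) is expected to be modest, leaning upward. Compound 4 is estimated to give 70% in this assay, within a range from 45% to 95%.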

Compound 4, a percentage reported as inhibition, in the whole organism at one dose (the size of the read-out at that dose, not a potency): 93%
Compound 4: middle estimate off by 23 percentage points, on the low side; the range from low to high includes it.
By their numbers in this assay, from the lowest: compounds 1 and 3 (each within the scatter of the next); then compounds 4 and 2 (each within the scatter of the next).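

The exchange on the sulfonyl sulfur gives a number 31 percentage points higher from compound 1 to compound 4 (beyond the scatter) in this assay and shows that a large rise from compound 1 does not depend on the ethoxy group of compound 2, since the group entering in compound 4 is made up of carbon and a single sulfur and contains no oxygen. Compound 4 at 93% and compound 2 at 96% lie within the scatter of each other, so two different replacements of the 5-(methylsulfanyl)thiophen-2-yl group reach the same level, while compound 3 goes against any general rise with a number 1 percentage points higher from compound 1 to compound 3 (within the scatter) as its step. No measurement at hand accounts for the step from the methylsulfanyl-bearing group to the group of compound 4.

The compounds shown leave open how much of the rise belongs to the loss of the methylsulfanyl group itself and how much to the group that enters, as a thiophene with no substituent at all is not among them. They also leave open whether a longer carbon chain, such as butyl, or a halogen such as chlorine on the thiophene would hold the level of compound 4 or fall back to that of compound 1.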